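From a halogenated phenyl to a furan-3-yl dienone

A few compounds are considered here, and "the series" means these few. Any claim that something is new, unique, unknown or untested is made for them only; others in the source may bear on it.

Three dienones share one core. In a functional assay on HeLa cells (Homo sapiens) for cytotoxicity, read by sulforhodamine B assay, with a stated time of 48 h (a higher number here means a weaker inhibitor, a lower number a stronger inhibitor), compound 1 `CC1=C(/C=C/C(=O)/C=C/c2ccccc2)C(C)(C)CCC1` gives 70200 nM, compound 2 `CC1=C(/C=C/C(=O)/C=C/c2ccc(Cl)cc2)C(C)(C)CCC1` gives 33200 nM, and compound 3 `CC1=C(/C=C/C(=O)/C=C/c2ccccc2Br)C(C)(C)CCC1` gives 57900 nM. Compound 3 stands second highest of the three, within the scatter of compound 1 and of compound 2 alike. The measured steps are a 2.1-fold lower number from compound 1 to compound 2 (0.33 log units; beyond the scatter), a 1.2-fold lower number from compound 1 to compound 3 (0.08 log units; within the scatter) and a 1.7-fold higher number from compound 2 to compound 3 (0.24 log units; within the scatter). Compound 4 `CC1=C(/C=C/C(=O)/C=C/c2ccoc2)C(C)(C)CCC1` differs from compound 3 by furan-3-yl in place of 2-bromophenyl on a double-bonded chain carbon bound to a double-bonded chain carbon. Among the measured compounds shown here, no measured step exchanges the aromatic ring itself; the three steps only vary halogens on it and move the number little. For compound 4 the expected step is a 1.1-fold higher number from compound 3 to compound 4 (0.05 log units; within the scatter), at most modest in either direction. The estimate for compound 4 in this assay is 65000 nM, from 30000 nM to 140000 nM.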

Compound 4, half-maximal inhibitory concentration: 88400 nM
For compound 4 the middle estimate is 1.4-fold (0.13 log units) below the measured one; the measured number falls inside the stated range.
By their numbers in this assay, from the lowest: compounds 2, 3, 1 and 4 (each within the scatter of the next, the first and the last beyond it).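

Exchanging the aromatic ring itself, on a double-bonded chain carbon bound to a double-bonded chain carbon, stays within the scatter in this assay for furan-3-yl in place of phenyl, with a 1.3-fold higher number from compound 1 to compound 4 (0.10 log units; within the scatter), and for furan-3-yl in place of 2-bromophenyl, with a 1.5-fold higher number from compound 3 to compound 4 (0.18 log units; within the scatter). Only furan-3-yl in place of 4-chlorophenyl goes beyond the scatter, with a 2.7-fold higher number from compound 2 to compound 4 (0.43 log units; beyond the scatter). Nothing measured here accounts for these differences. The compounds shown leave open how a pyridine ring or an aminophenyl group would read at this place. They also leave open whether a chloro group on the furan ring would lower the number as it does on the phenyl ring.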